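The source may report more compounds than this note shows. Statements on the series, on what has been measured and on what is new or still open speak of the compounds shown alone.

In a functional assay on HeLa cells (Homo sapiens) for cytotoxicity, read by MTT assay, with a stated time of 48 h (on this read-out lower numbers stand for stronger inhibition and higher numbers for weaker inhibition), compound 1 (`Cc1n[nH]c2c1C(c1ccc(N(C)C)cc1)C=C(N)N2`) gives 27400 nM and compound 2 (`Cc1n[nH]c2c1C(c1ccc(N(C)C)cc1)C(C(=O)N/N=C1/C(=O)Nc3ccccc31)=C(N)N2`) gives 52900 nM. These two values lie within the usual scatter of each other, so compound 2 stands level with compound 1, and the numbers do not rank the pair. Among the compounds with values here, both values belong to weak cytotoxic readings on this scale, and the series so far offers only these two points.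

Compound 3 (`Cc1n[nH]c2c1C(c1ccc(N(C)C)cc1)C(C(N)=O)=C(N)N2`) has not yet been measured. The change that leads to it from compound 2 is a hydrogen atom in place of a group of 11 heavy atoms (8 carbon, 2 nitrogen, 1 oxygen; one five-membered non-aromatic ring with 1 hetero atom, one six-membered aromatic ring of carbon only), on an amide-type nitrogen, so that a hydrogen atom now sits on the amide-type nitrogen in place of the larger group. Within the data shown here, no measured pair shows directly what this change does, which leaves the expectation on thin ground. Among the measured compounds shown here, the only guide is that compound 1 at 27400 nM and compound 2 at 52900 nM sit close together, so no step beyond the scatter is expected in this assay. The estimate amounts to an expected 1.3-fold lower number from compound 2 to compound 3 (0.12 log units; within the scatter). For compound 3 the expected value is 40000 nM, with an estimated range from 14000 nM to 100000 nM.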

Compound 3, half-maximal inhibitory concentration: 5770 nM
Compound 3: middle estimate off by 6.9-fold (0.84 log units), on the high side; the measured number lies below the stated range.
By their numbers in this assay, from the lowest: compound 3; then compounds 1 and 2 (each within the scatter of the next).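

In this assay the double-bonded ring carbon turns out to respond to substitution: carbamoyl in place of hydrogen there gives a 4.7-fold lower number from compound 1 to compound 3 (0.68 log units; beyond the scatter), a step beyond the scatter. What sits on the amide-type nitrogen of that carbamoyl also counts, for a hydrogen atom in place of the group of 11 heavy atoms gives a 9.2-fold lower number from compound 2 to compound 3 (0.96 log units; beyond the scatter), so the gain seen with carbamoyl does not survive that larger group. Compound 1 and compound 2 stood level with each other and gave no hint of either effect, and nothing measured here says why the number falls.

Going by these compounds, it remains open whether a nitrile or a carboxylic acid on the double-bonded ring carbon would match carbamoyl, and whether a single methyl group on the amide-type nitrogen would keep the number of compound 3 or lose it, which would show how much substitution that nitrogen tolerates. On these data alone, it is also open whether the gain holds when the dimethylamino group of the shared core gives way to a methoxy group.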